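Oxazolyl replacement on the dihydropyrimidinone series

The compounds below may be only part of what the source reports. "The series", "measured", "known", "first", "only" and "open" are said of these compounds alone.

Measured so far:
- compound 1 `CC1=C(C(=O)C2CC2)C(c2ccco2)NC(=O)N1` — 2%
- compound 2 `CC1=C(C(=O)C2CC2)C(c2ccsc2)NC(=O)N1` — 2%

In an assay on membranes from CHO cells for displacement of a labelled ligand from adenosine receptor A1 (Homo sapiens), read by scintillation counting, with a stated time of 60 min, tested at 1 uM (a higher number here means more inhibition at the concentration tested (going by the name of the read-out), a lower number less inhibition), compound 2 gives 2%, level with compound 1 at the digits printed. Among the compounds with values here, the single measured step, no change at the digits printed from compound 1 to compound 2 (within the scatter), comes from exchanging the group on the saturated ring carbon and lies within the scatter; neither value shows any inhibition worth the name.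

Compound 3 `CC1=C(c2ncc(C)o2)C(c2ccsc2)NC(=O)N1` differs from compound 2 at a different site, on a double-bonded ring carbon: 5-methyl-1,3-oxazol-2-yl in place of cyclopropylcarbonyl on a double-bonded ring carbon. Within the data shown here, no measured pair touches this position, so the step from compound 1 to compound 2 does not bear on it directly. Among the measured compounds shown here, with both measured compounds at the floor of this assay, and no step yet beyond the scatter, the expectation for compound 3 is that a number 3 percentage points higher from compound 2 to compound 3 (within the scatter) stays within the scatter. Compound 3 is therefore estimated at 5%, with a range from -5% to 25%, a low-inhibition result rather than a measurable potency.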

Compound 3, a percentage reported as inhibition, at one concentration (the size of the read-out at that concentration, not a potency): 34%
Beside the measured number, compound 3's estimate is 29 percentage points below it; the measured number lies above the stated range.
By their numbers in this assay, from the lowest: compounds 1 and 2 (each within the scatter of the next); then compound 3.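

In this assay, the double-bonded ring carbon responds to substitution, whereas the earlier exchange on the saturated ring carbon did not: 5-methyl-1,3-oxazol-2-yl in place of cyclopropylcarbonyl gives a number 32 percentage points higher from compound 2 to compound 3 (beyond the scatter). This is the only step shown that lies beyond the scatter, and it shows that cyclopropylcarbonyl is not needed at this position for inhibition to be seen, at least with thiophen-3-yl held on the saturated ring carbon. Nothing available accounts for the rise.

The compounds shown do not separate the contribution of the five-membered aromatic ring from that of its methyl group, nor show whether the rise carries over to the furan-2-yl compound. Replacing that methyl group with an amine or a longer chain also remains an open question.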